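The compounds below may be only part of what the source reports. "The series", "measured", "known", "first", "only" and "open" are said of these compounds alone.

Measured so far in a functional assay on HepG2 cells (Homo sapiens) for cytotoxicity, read by MTT assay, with a stated time of 72 h; on this read-out lower numbers stand for stronger inhibition and higher numbers for weaker inhibition: compound 1 `Cc1cc(=O)n(-c2ccc(Br)cc2F)nc1C(=O)Nc1ccc(Oc2ncnc3ccsc23)cc1` gives 10600 nM; compound 2 `Cc1cc(=O)n(-c2ccc(F)cc2)nc1C(=O)Nc1ccc(Oc2ncnc3ccsc23)cc1` gives 2110 nM; compound 3 `Cc1cc(=O)n(-c2ccc(F)c(F)c2)nc1C(=O)Nc1ccc(Oc2ncnc3ccsc23)cc1` gives 9230 nM.

Compound 2 stands lowest of the three, with a 5.0-fold lower number from compound 1 to compound 2 (0.70 log units; beyond the scatter) and a 4.4-fold higher number from compound 2 to compound 3 (0.64 log units; beyond the scatter); the pair compound 1 to compound 3 shows a 1.1-fold lower number from compound 1 to compound 3 (0.06 log units; within the scatter).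

Compound 4 `Cc1cc(=O)n(-c2ccc(F)cc2)nc1C(=O)Nc1ccc(Oc2ncnc3ccsc23)c(F)c1` differs from compound 2 by fluoro in place of hydrogen on an aromatic carbon. Among the compounds with values here, the only measured step of the same kind is a 4.4-fold higher number from compound 2 to compound 3 (0.64 log units; beyond the scatter), where the fluoro entered a different six-membered aromatic ring of carbon only. Nothing measured touches the ring changed here. A modest rise of the number in this assay is expected at most, possibly none beyond the scatter. Compound 4 is therefore estimated at 3500 nM (range 1400 nM to 9000 nM). This estimate corresponds to a 1.7-fold higher number from compound 2 to compound 4 (0.22 log units; within the scatter).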

Compound 4, half-maximal inhibitory concentration: 470 nM
Compound 4: middle estimate off by 7.4-fold (0.87 log units), on the high side, and the stated range ends above it.
By their numbers in this assay, from the lowest: compound 4; then compound 2; then compounds 3 and 1 (each within the scatter of the next).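

Fluoro in place of hydrogen on this ring, ortho to a large group and meta to a large group, gives a 4.5-fold lower number from compound 2 to compound 4 (0.65 log units; beyond the scatter) in this assay and shows that the number can fall below that of compound 2 through a change on this ring. The same exchange on the other ring gives a 4.4-fold higher number from compound 2 to compound 3 (0.64 log units; beyond the scatter) and so runs the opposite way in these two pairs. Nothing at hand explains the fall.

Open: whether a chloro group, a methoxy group or an amine at this carbon gives a step in the same direction. On these data alone, also open: whether the fall holds with 3,4-difluorophenyl or 4-bromo-2-fluorophenyl on the aromatic nitrogen.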